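Phenyl for Pyridin-4-yl: From Compound 2 to Compound 3

The source may report more compounds than this note shows. Statements on the series, on what has been measured and on what is new or still open speak of the compounds shown alone.

Compound 1 `O=C(NO)c1ccc(CN(Cc2ccccc2)S(=O)(=O)c2c(F)c(F)c(F)c(F)c2F)cc1` and compound 2 `O=C(NO)c1ccc(CN(Cc2ccncc2)S(=O)(=O)c2cc(F)c(F)c(F)c2F)cc1` have both been tested in an assay on isolated protein for inhibition of histone deacetylase 11 (Homo sapiens), read by mobility shift assay; a lower number here means a stronger inhibitor, a higher number a weaker inhibitor. Compound 1 gives 122 nM, while compound 2 gives 472 nM, the higher of the two numbers and beyond the scatter from compound 1. Compound 3 `O=C(NO)c1ccc(CN(Cc2ccccc2)S(=O)(=O)c2cc(F)c(F)c(F)c2F)cc1` has not yet been measured. It differs from compound 2 by phenyl in place of pyridin-4-yl on a saturated chain carbon bound to a sulfonamide nitrogen. Among the compounds with values here, no measured pair shows this step directly, but because compound 1 also carries the benzyl and gives 122 nM, a moderate move toward lower numbers is expected a 2.6-fold lower number from compound 2 to compound 3 (0.42 log units; beyond the scatter). For compound 3 the estimate is 180 nM, within 80 nM to 400 nM.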

Compound 3, half-maximal inhibitory concentration: 115 nM
Compound 3: middle estimate off by 1.6-fold (0.19 log units), on the high side, and the stated range covers the measured number.
By their numbers in this assay, from the lowest: compounds 3 and 1 (each within the scatter of the next); then compound 2.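

In this assay, within the data shown here, phenyl in place of pyridin-4-yl on a saturated chain carbon bound to a sulfonamide nitrogen gives a 4.1-fold lower number from compound 2 to compound 3 (0.61 log units; beyond the scatter), a first direct reading of this change, and the step lies beyond the scatter. Hydrogen in place of fluoro on an aromatic carbon gives a 1.1-fold lower number from compound 1 to compound 3 (0.03 log units; within the scatter), which lies within the scatter. Nothing measured here explains either step.

On these data alone, it remains open how a cyclohexyl group or a longer chain would read in place of phenyl at that position. Also open, as far as these compounds go, is whether an amine or a methoxy group in place of that fluoro would likewise stay within the scatter.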